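This account rests on a few compounds, and the source may have more. Where it says the series, first, only, none or still open, it means among the compounds named here.

In a physicochemical assay for solubility, in phosphate buffer, measured as thermodynamic solubility, at pH 7.4 (a lower number here means a less soluble compound, a higher number a more soluble compound), compound 1 `CS(=O)(=O)NC(=O)CCc1cn(-c2ccc(F)cc2)nc1-c1ccc(Cl)cc1` gives 25000 nM. Compound 2 `CS(=O)(=O)NC(=O)CCc1cn(-c2cccc(Br)c2)nc1-c1ccc(Cl)cc1` stands at < 5000 nM, which is a limit of the assay and not a number. Compound 3 `CS(=O)(=O)NC(=O)CCc1cn(-c2ccc(C(F)(F)F)cc2)nc1-c1ccc(Cl)cc1` carries 4-(trifluoromethyl)phenyl in place of 3-bromophenyl on an aromatic nitrogen. For the measured compounds named here, the only measured step that bears on this change, also made at that nitrogen, is an at least 5.0-fold lower number from compound 1 to compound 2 (0.69 log units; beyond the scatter). On these data alone, its full size stays open, since it ends on a limit. The expected step in this assay is a number no lower from compound 2 to compound 3 (the limit leaves the size open), with none beyond the scatter foreseen. Compound 3 is estimated at 5000 nM, within a range of 2000 nM to 15000 nM.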

Compound 3, solubility: 50000 nM
Compound 3: middle estimate off by 10-fold (1.00 log units), on the low side, outside the stated range (above it).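

In this assay, the group on the aromatic nitrogen moves the read-out both ways: 4-(trifluoromethyl)phenyl in place of 3-bromophenyl gives an at least 10-fold higher number from compound 2 to compound 3 (1.00 log units; beyond the scatter), so the earlier drop does not hold for every replacement of 4-fluorophenyl. Trifluoromethyl in place of fluoro on an aromatic carbon gives a 2.0-fold higher number from compound 1 to compound 3 (0.30 log units; within the scatter). The value of compound 2 is a limit of the assay, so the size of that step stays open: the limit of < 5000 nM in this assay, at which 1 of the 3 values shown sits.

On these data alone, whether the bromine or its place on the ring matters stays open, and 4-bromophenyl would separate the two. As far as these compounds go, how an amine or a carboxylic acid on this ring would read is also open.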